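Swapping bromo for amino on the aryl ring

A few compounds are considered here, and "the series" means these few. Any claim that something is new, unique, unknown or untested is made for them only; others in the source may bear on it.

Measured so far:
compound 1 `COc1ccc(/C=C2\Cc3c(cc(OC)c(OC)c3OC)C2=O)cc1`, 750 nM
compound 2 `COc1ccc(/C=C2\Cc3c(cc(OC)c(OC)c3OC)C2=O)cc1OC`, 7470 nM
compound 3 `COc1ccc(/C=C2\Cc3c(cc(OC)c(OC)c3OC)C2=O)cc1Br`, 389 nM

In a functional assay on PC-3 cells (Homo sapiens) for antiproliferative activity, read by MTT assay, with a stated time of 48 h (on this read-out lower numbers stand for stronger inhibition of growth and higher numbers for weaker inhibition of growth), compound 3 gives the lowest number of the three. Its nearest neighbour is compound 1, and that gap, a 1.9-fold lower number from compound 1 to compound 3 (0.29 log units; within the scatter), is within the scatter, so the two cannot be ranked. Compound 2 stands far off: a 19-fold lower number from compound 2 to compound 3 (1.28 log units; beyond the scatter).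

Compound 4 `COc1ccc(/C=C2\Cc3c(cc(OC)c(OC)c3OC)C2=O)cc1N` differs from compound 3 in one place: amino in place of bromo on an aromatic carbon, ortho to a methoxy group and meta to a large group.

Among the compounds with values here, two measured steps bear on this. Putting methoxy on that carbon cost a great deal, a 10-fold higher number from compound 1 to compound 2 (1.00 log units; beyond the scatter), while bromo changed little, a 1.9-fold lower number from compound 1 to compound 3 (0.29 log units; within the scatter). Amino is smaller than methoxy and, unlike bromo, brings a hydrogen-bond donor and acceptor, so the picture is mixed: no step among the measured compounds shows what a donor does here. The likeliest outcome seems a move back toward compound 1, with a real chance of a larger loss as seen for compound 2, and a smaller chance of no change.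

Compound 4 is therefore expected to give about 800 nM in this assay, within 150 nM to 4000 nM, a step of a 2.1-fold higher number from compound 3 to compound 4 (0.31 log units; beyond the scatter).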

Compound 4, concentration for 50% growth inhibition: 456 nM
Estimate against measurement, compound 4: 1.8-fold (0.24 log units) above; low and high end bracket the measured number.
By their numbers in this assay, from the lowest: compounds 3, 4 and 1 (each within the scatter of the next); then compound 2.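

In this assay amino on this aromatic carbon cannot be told apart from bromo (a 1.2-fold higher number from compound 3 to compound 4 (0.07 log units; within the scatter)) or from the hydrogen it replaces (a 1.6-fold lower number from compound 1 to compound 4 (0.22 log units; within the scatter)). Against methoxy at the same carbon the picture is clear (a 16-fold lower number from compound 2 to compound 4 (1.21 log units; beyond the scatter)), so among the four compounds shown, methoxy alone stands apart, while amino, which brings a hydrogen-bond donor and acceptor, and bromo, which brings neither, both sit with hydrogen. Nothing in the data available here explains why methoxy differs from the other three groups.

The compounds shown leave open whether this carbon also accepts other small groups, such as hydroxyl, fluoro or methyl, and whether a hydroxyl would fall with amino or with methoxy. They also leave open how much can be built onto the amino nitrogen, for instance as a dimethylamino group or an acetamide, and whether such a group would keep the numbers of compound 3 and compound 4 or move toward that of compound 2.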